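Removing the Acid: What Compound 4 Should Show

The source may hold more compounds than are shown below. What is called first, only, known or untested is meant among the compounds shown, and "the series" means these compounds.

Compound 3 `O=C(O)CCc1ccc(NCc2ccc(C(=O)O)cc2)cc1` stands lowest of the three measured compounds in a functional assay on CHO cells for agonist activity at Free fatty acid receptor 1 (Homo sapiens), read by reporter gene assay (on this read-out higher numbers stand for larger maximal responses and lower numbers for smaller maximal responses), where compound 3 gives 9%. Compound 1 `Cc1ccc(CNc2ccc(CCC(=O)O)cc2)cc1` gives 152% and compound 2 `O=C(O)CCc1ccc(NCc2ccccc2)cc1` gives 144%; the step between them is a number 8 percentage points lower from compound 1 to compound 2 (within the scatter). Compound 4 `COc1ccc(CNc2ccc(CCC(=O)O)cc2)cc1` differs from compound 3 by methoxy in place of carboxy on an aromatic carbon. Among the measured compounds shown here, two measured steps bear directly on this change, both running the opposite way: a number 143 percentage points lower from compound 1 to compound 3 (beyond the scatter) and a number 135 percentage points lower from compound 2 to compound 3 (beyond the scatter). Because the carboxy leaves in the step that produced a number 143 percentage points lower from compound 1 to compound 3 (beyond the scatter) and a number 135 percentage points lower from compound 2 to compound 3 (beyond the scatter), a large rise back toward the values of compound 1 and compound 2 is expected. The expected step is a number 131 percentage points higher from compound 3 to compound 4 (beyond the scatter). For compound 4 the estimate is 140%, ranging from 100% to 170%.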

Compound 4, largest response reached (reported as percent of maximum), in percent of the reference or control that the assay uses: 159%
For compound 4 the middle estimate is 19 percentage points below the measured one; the range from low to high includes it.
By their numbers in this assay, from the lowest: compound 3; then compounds 2, 1 and 4 (each within the scatter of the next, the first and the last beyond it).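

In this assay, methoxy on this aromatic carbon, para to a large group, fully reverses the loss seen with carboxy, giving a number 150 percentage points higher from compound 3 to compound 4 (beyond the scatter). It is also the first substituent here to separate from hydrogen, with a number 15 percentage points higher from compound 2 to compound 4 (beyond the scatter), while it cannot be told apart from methyl, with a number 7 percentage points higher from compound 1 to compound 4 (within the scatter). Nothing available explains these steps. As far as these compounds go, whether a hydroxy group, an amine or a longer chain such as ethoxy would hold the response on this carbon remains open. So does whether methoxy would keep it on another carbon of this ring.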